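A larger ring with a phenyl at the amine position of compound 3

The source may report more compounds than this note shows. Statements on the series, on what has been measured and on what is new or still open speak of the compounds shown alone.

Three compounds share one core and differ only in the group on an aromatic carbon next to the ring nitrogen. In a functional assay on CHO-K1 cells for antagonist activity at transient receptor potential cation channel subfamily V member 1 (Homo sapiens), read by FLIPR (a lower number here means a stronger inhibitor, a higher number a weaker inhibitor), compound 1 `CC(C(=O)NCc1ccc(C(F)(F)F)nc1Nc1ccccc1)c1ccc(NS(C)(=O)=O)c(F)c1` gives 1400 nM, compound 2 `CC(C(=O)NCc1ccc(C(F)(F)F)nc1NCc1ccccc1)c1ccc(NS(C)(=O)=O)c(F)c1` gives 203 nM, and compound 3 `CC(C(=O)NCc1ccc(C(F)(F)F)nc1N1CCCC1)c1ccc(NS(C)(=O)=O)c(F)c1` gives 211 nM, so compound 3 sits together with compound 2 and well apart from compound 1: a 6.6-fold lower number from compound 1 to compound 3 (0.82 log units; beyond the scatter), a 6.9-fold lower number from compound 1 to compound 2 (0.84 log units; beyond the scatter), but a 1.0-fold higher number from compound 2 to compound 3 (0.02 log units; within the scatter). Compound 4 `CC(C(=O)NCc1ccc(C(F)(F)F)nc1N1CCC(c2ccccc2)CC1)c1ccc(NS(C)(=O)=O)c(F)c1` carries 4-phenylpiperidin-1-yl in place of pyrrolidin-1-yl on an aromatic carbon. The step from compound 2 to compound 3 shows that a group holding a phenyl and one without give the same result, while only the anilino group of compound 1 falls behind. A change no larger than the scatter is therefore expected, a 1.3-fold lower number from compound 3 to compound 4 (0.12 log units; within the scatter). Compound 4 is expected to give 160 nM, between 45 nM and 600 nM.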

Compound 4, half-maximal inhibitory concentration: 25 nM
The estimate for compound 4 lay 6.4-fold (0.81 log units) above the measured number, and the stated range ends above it.
By their numbers in this assay, from the lowest: compound 4; then compounds 2 and 3 (each within the scatter of the next); then compound 1.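

Compound 2 and compound 3 had matched in this assay. The 4-phenylpiperidin-1-yl group gives an 8.4-fold lower number from compound 3 to compound 4 (0.93 log units; beyond the scatter) and an 8.1-fold lower number from compound 2 to compound 4 (0.91 log units; beyond the scatter), so this position can hold much better inhibitors than those two suggested. Compound 4 is the strongest inhibitor of the four, and the widest gap is a 56-fold lower number from compound 1 to compound 4 (1.75 log units; beyond the scatter) against the anilino group. Nothing at hand gives a reason for this gain.

The compounds shown leave open whether the gain comes from the six-membered ring, the added phenyl, or only the two together. Plain piperidin-1-yl would help to separate these, while morpholin-4-yl would test a ring oxygen at this position.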